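The source may report more compounds than this note shows. Statements on the series, on what has been measured and on what is new or still open speak of the compounds shown alone.

Of the compounds shown here, three have been tested in a functional assay on C8166 cells (Homo sapiens) for cytotoxicity, read by MTT assay, with a stated time of 72 h; on this read-out higher numbers stand for lower toxicity in this test and lower numbers for higher toxicity in this test. Compound 2 (`Cc1ccc(S(=O)(=O)N2CC3(C[C@H]2C(=O)NN)SCCS3)cc1`) gives > 519000 nM, and this is a limit, not a number. Compound 3 (`C/C(=N\NC(=O)Cn1c(=O)c(C)nc2ccccc21)c1ccc(Cl)cc1`) gives > 543000 nM, which is also a limit. For the measured compounds named here, compound 1 (`Cc1nc2ccccc2n(CC(=O)N/N=C/c2ccc(N(C)C)cc2)c1=O`) is the only one with a true number, 355000 nM. Compound 2 therefore has no exact place on the scale, and all that can be reported for it is its limit.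

Compound 4 (`COc1ccccc1/C=N/NC(=O)[C@@H]1CC2(CN1S(=O)(=O)c1ccc(C)cc1)SCCS2`) differs from compound 2 in one place, on an amide-type nitrogen. There the amino group leaves and a larger group containing a six-membered aromatic ring of carbon only enters: a group of 10 heavy atoms (8 carbon, 1 nitrogen, 1 oxygen; one six-membered aromatic ring of carbon only) in place of one nitrogen atom, on an amide-type nitrogen.

Going by the values given here, no measured pair of compounds shows what this kind of change does, so any forecast is rough. Compound 1, which also has a double bond outside its aromatic rings, reaches a true number at 355000 nM, so a number is a plausible outcome for compound 4. Compound 3 has such a double bond too, yet it stays a limit at > 543000 nM, so compound 4 may also give only a limit. A moderate move towards lower numbers, meaning somewhat higher toxicity, is expected, and the estimated size is an at least 2.3-fold lower number from compound 2 to compound 4 (0.37 log units; beyond the scatter). For compound 4 the estimate is 220000 nM, with an expected range from 60000 nM to 450000 nM.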

Compound 4, half-maximal cytotoxic concentration: 388000 nM
For compound 4 the middle estimate is 1.8-fold (0.25 log units) below the measured one; the range from low to high includes it.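

In this assay compound 4 gives 388000 nM as a true number, so putting the larger group with its six-membered aromatic ring of carbon only in place of the amino group, on an amide-type nitrogen, leaves a compound whose value falls within the tested range. The change reads as an at least 1.3-fold lower number from compound 2 to compound 4 (0.12 log units; that floor lies within the scatter), and since that floor lies within the usual scatter, these two compounds do not establish a real gain in toxicity, though the true gap could be larger. Only a floor can be given because compound 2 has a limit and not a number: the limit of > 519000 nM in this assay, at which 1 of the 4 values shown sits.

The compounds shown leave open which part of the entering group matters, the six-membered aromatic ring or the double bond outside aromatic rings, as no compound carries only one of them at this place. They also leave open what a simple methyl group, a longer carbon chain or a carboxylic acid on this amide-type nitrogen would do in the same test.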